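A few compounds are considered here, and "the series" means these few. Any claim that something is new, unique, unknown or untested is made for them only; others in the source may bear on it.

Compound 1, with the structure `CO[C@H]1C[C@H](Oc2cc(F)c(F)c(-c3ccc4c(c3)CC[C@H](CCC(=O)O)O4)c2)C1`, was tested in a functional assay on CHO cells for agonist activity at Free fatty acid receptor 1 (Homo sapiens), read by calcium flux; on this read-out higher numbers stand for an effect only at larger amounts of compound and lower numbers for an effect already at smaller amounts. In this assay compound 1 reaches only the limit of the measurement, > 100000 nM. Compound 2, `CC(C)Nc1ccccc1-c1cc(F)c(OCCCC(=O)O)c(F)c1`, carries a different group on the shared core. In this assay compound 2 likewise gives only the limit, > 100000 nM. Compound 3, `CO[C@H]1C[C@H](Oc2cc(F)c(F)c(-c3cc(F)c(OCCCC(=O)O)c(F)c3)c2)C1`, joins the two sides of these compounds into one molecule. In this assay compound 3 also stops at the limit, > 100000 nM, so no number for it is known. Thus (the limit of > 100000 nM in this assay, at which 3 of the 3 values shown sit), and all three compounds stand where no effect was seen within the tested amounts.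

Compound 4, `CO[C@H]1C[C@H](Oc2cc(F)c(F)c(-c3cc(F)c(SCCCC(=O)O)c(F)c3)c2)C1`, differs from compound 3 in one place: (3-carboxypropyl)sulfanyl in place of 3-carboxypropoxy on an aromatic carbon. Among the compounds with values here, no measured pair shows what such a swap does in this assay, so the expected step for compound 4 is simply no clear change beyond the scatter, a step that the limit leaves unreadable from compound 3 to compound 4. For compound 4 the expected result is therefore again close to the limit, 150000 nM, with a range from 30000 nM to 1000000 nM, and most likely only a limit will be reported.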

Compound 4, half-maximal effective concentration: > 100000 nM
Compound 4 was reported as a limit (the forecaster's own chance of this, stated with the estimate: 85%); the middle value does not contradict the limit.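

Compound 3 and compound 4 each stop at a limit, so no step can be read between them: the limit of > 100000 nM in this assay, at which 4 of the 4 values shown sit.

On these data alone, what the swap of 3-carboxypropoxy for (3-carboxypropyl)sulfanyl does, and whether any compound of this kind gives a measurable effect in this assay remain open.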